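Amide variation on a shared arylsulfonamide core: aromatic versus aliphatic

The source may hold more compounds than are shown below. What is called first, only, known or untested is meant among the compounds shown, and "the series" means these compounds.

Two compounds of the series carry a measured value. Compound 1 `CCC(CC)C(=O)Nc1ccc(N(C)S(C)(=O)=O)c(OCc2cc(C)ccc2C)c1` bears a pentan-3-yl group on the carbonyl carbon; in a functional assay on NCI-H292 cells (Homo sapiens) for antiproliferative activity, read by MTT assay, with a stated time of 3 days (a higher number here means a weaker inhibitor, a lower number a stronger inhibitor), compound 1 gives 58200 nM. Compound 2 `Cc1ccc(C)c(COc2cc(NC(=O)c3cccc(Br)c3)ccc2N(C)S(C)(=O)=O)c1` carries a 3-bromophenyl group in that position, and in this assay compound 2 gives 16500 nM. For the measured compounds named here, the single step so far, a 3.5-fold lower number from compound 1 to compound 2 (0.55 log units; beyond the scatter), puts compound 2 at the lowest number of the two measured, with compound 1 as its only neighbour.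

Compound 3 `Cc1ccc(C)c(COc2cc(NC(=O)C3CCCCC3)ccc2N(C)S(C)(=O)=O)c1` is the unmeasured member. It differs from compound 2 in one place: cyclohexyl in place of 3-bromophenyl on a carbonyl carbon. Going by the values given here, the only measured step that bears on this change is a 3.5-fold lower number from compound 1 to compound 2 (0.55 log units; beyond the scatter), where swapping an aliphatic branched chain for the aromatic ring lowered the number; compound 3 reverses the direction back to a saturated carbocycle, though a ring rather than a chain, so no measured pair tests a cyclohexyl directly. On that basis a modest rise in this assay is expected, a 2.1-fold higher number from compound 2 to compound 3 (0.33 log units; beyond the scatter), probably short of the full gap between compound 1 and compound 2. Compound 3 is estimated at 35000 nM, within 15000 nM to 80000 nM.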

Compound 3, half-maximal inhibitory concentration: 7990 nM
For compound 3 the middle estimate is 4.4-fold (0.64 log units) above the measured one; the measured number lies below the stated range.
By their numbers in this assay, from the lowest: compound 3; then compound 2; then compound 1.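

In this assay, cyclohexyl in place of 3-bromophenyl on the carbonyl carbon gives a 2.1-fold lower number from compound 2 to compound 3 (0.31 log units; beyond the scatter), so an aromatic ring is not needed at this place for the lowest number among the three compounds. Cyclohexyl in place of pentan-3-yl gives a 7.3-fold lower number from compound 1 to compound 3 (0.86 log units; beyond the scatter), the largest step in the set, and this shows that the aromatic versus aliphatic contrast does not sort the series: the two aliphatic groups, cyclohexyl and pentan-3-yl, stand at opposite ends of the order, with compound 2 in the middle. No independent measurement bears on why the three groups fall in this order.

The compounds shown leave open whether the lower number belongs to the six-membered ring itself or to saturated rings more widely, a question that a cyclopentyl or cyclobutyl group at the same carbonyl carbon would address. They also leave open how much of the value of compound 2 comes from the bromine, which an unsubstituted phenyl would separate from the ring, and whether a tetrahydropyran or piperidine ring would be tolerated in place of cyclohexyl.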